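Swapping one aryl group for another on a shared core

The source may report more compounds than this note shows. Statements on the series, on what has been measured and on what is new or still open speak of the compounds shown alone.

Compound 2 `c1ccc(C(c2cccnc2)N2CCN(c3ncnc4c3cnn4-c3ccccc3)CC2)cc1` carries pyridin-3-yl on a saturated chain carbon bound to an amine nitrogen in a ring and an aromatic carbon. In a functional assay on cells (Rhabdomyosarcoma cell, Homo sapiens) for cytotoxicity (a higher number here means a weaker inhibitor, a lower number a stronger inhibitor), compound 2 gives > 25000 nM, which is a limit of the assay rather than a number. Compound 1 `Cc1noc(C)c1C(c1ccccc1)N1CCN(c2ncnc3c2cnn3-c2ccccc2)CC1` differs from it only in carrying 3,5-dimethyl-1,2-oxazol-4-yl at that position. In this assay compound 1 gives > 25000 nM, again a limit. Among the measured compounds shown here, the single measured step, a step that the two limits leave unreadable from compound 1 to compound 2, therefore cannot be sized, since (the limit of > 25000 nM in this assay, at which 2 of the 2 values shown sit). Compound 3 `N#Cc1ccc(C(c2ccccc2)N2CCN(c3ncnc4c3cnn4-c3ccccc3)CC2)cc1` has not been measured; it differs from compound 2 in that (4-cyanophenyl in place of pyridin-3-yl on a saturated chain carbon bound to an amine nitrogen in a ring and an aromatic carbon). For the measured compounds named here, no measured step bears on this change in a readable way, as both measured compounds sit at the limit, so there is no basis for predicting a shift in either direction beyond the scatter. The expectation for compound 3 is that it stays at or near the same limit, so a step that the limit leaves unreadable from compound 2 to compound 3 is expected. The estimate for compound 3 is 30000 nM, with a range from 8000 nM to 100000 nM.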

Compound 3, half-maximal inhibitory concentration: > 25000 nM
Compound 3 gave a limit, no number; the forecaster's own chance of this, stated with the estimate: 75%; the middle value is on the limit's open side.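

In this assay compound 3 gives > 25000 nM and this is a limit of the assay, not a number. The steps among compound 1, compound 2 and compound 3 therefore cannot be read: the limit of > 25000 nM in this assay, at which 3 of the 3 values shown sit. Still open, as far as these compounds go, is how strong each compound really is, and whether pyridin-3-yl, 4-cyanophenyl and 3,5-dimethyl-1,2-oxazol-4-yl differ at all in their effect.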